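The source may hold more compounds than are shown below. What is called first, only, known or untested is meant among the compounds shown, and "the series" means these compounds.

Compound 1 `Cc1cc(-c2cccc(F)c2)cc(C)c1Oc1cc(N)nc(Nc2ccc(C#N)cc2)n1`: 24700 nM
Compound 2 `Cc1cc(-c2ccc(Cl)cc2)cc(C)c1Oc1cc(N)nc(Nc2ccc(C#N)cc2)n1`: 21500 nM

Among the compounds with values here, in a toxicity assay on MT4 cells (Homo sapiens) for cytotoxicity, read by MTT assay (a higher number here means that more compound is tolerated, a lower number that less compound is tolerated), compound 2 gives 21500 nM, which lies within the scatter of compound 1, the only other number available. Compound 3 `COc1cccc(-c2cc(C)c(Oc3cc(N)nc(Nc4ccc(C#N)cc4)n3)c(C)c2)c1` keeps the shared core and changes one group: 3-methoxyphenyl in place of 4-chlorophenyl on an aromatic carbon. Within the data shown here, the single measured step, a 1.1-fold lower number from compound 1 to compound 2 (0.06 log units; within the scatter), also exchanged one substituted phenyl group for another. Among the measured compounds shown here, it is the only guide, and it stayed within the scatter, so no step beyond the scatter is expected in this assay. The expected step is a 1.1-fold higher number from compound 2 to compound 3 (0.03 log units; within the scatter). Compound 3 is estimated at 23000 nM, with an expected range from 9000 nM to 60000 nM.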

Compound 3, half-maximal cytotoxic concentration: 19300 nM
Compound 3: the middle estimate sits 1.2-fold (0.08 log units) above what was measured, within the range that was stated.
By their numbers in this assay, from the lowest: compounds 3, 2 and 1 (each within the scatter of the next).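

At this position, para to a large group, a third substituted phenyl group again stays within the scatter in this assay: a 1.1-fold lower number from compound 2 to compound 3 (0.05 log units; within the scatter), and a 1.3-fold lower number from compound 1 to compound 3 (0.11 log units; within the scatter). Adding a hydrogen-bond acceptor to the phenyl group, as the 3-methoxyphenyl group does, therefore gives no step beyond the scatter against either 4-chlorophenyl or 3-fluorophenyl. No further measurement bears on this result. From the compounds shown here alone, all three groups here are substituted phenyl rings, so the effect of an amine, a carboxylic acid or a longer alkyl chain at this position stays open. Whether any such group would give a step beyond the scatter cannot be told from these compounds.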